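The source may hold more compounds than are shown below. What is called first, only, known or untested is meant among the compounds shown, and "the series" means these compounds.

Of the compounds shown here, three that share the core of compound 1 have been measured for agonist activity. In a functional assay on HEK293 cells for agonist activity at transient receptor potential cation channel subfamily V member 1 (Homo sapiens) (a lower number here means a smaller maximal response, a higher number a larger maximal response), compound 1 `CCCCCCCC/C=C\CCCCCCCCC(=O)N[C@@H]1C[C@H](C)CC[C@H]1C(C)C` gives 4.4%. Compound 2 `CC(C)[C@@H]1CC[C@@H](C)C[C@H]1NC(=O)c1ccc(-c2ccccc2)cc1` gives 7.8% in this assay, and compound 3 `CC(C)[C@@H]1CC[C@@H](C)C[C@H]1NC(=O)CCCCCCc1ccccc1` gives 8%. Compound 3 carries the top number of the three, but its gaps to compound 2 and to compound 1 both lie within the usual scatter of this assay, so the three compounds cannot be told apart on these numbers.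

Compound 4 `CC(C)[C@@H]1CC[C@@H](C)C[C@H]1NC(=O)CCCCCCCc1ccccc1` has not yet been measured in this assay. It differs from compound 3 in one place: benzyl in place of phenyl on a saturated chain carbon, six bonds along the chain from a carbonyl carbon. Among the measured compounds nothing shows what such a change does, since no pair among them differs in one place only. With compound 1, compound 2 and compound 3 all lying within the scatter of one another, the expected step is none beyond the scatter, that is no change at the digits printed from compound 3 to compound 4 (within the scatter) in this assay. Compound 4 is therefore estimated to give 8%, with a range from 2% to 16%.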

Compound 4, largest response reached (reported as efficacy), in percent of the reference or control that the assay uses: 5.5%
For compound 4 the middle estimate is 2.5 percentage points above the measured one, and the stated range covers the measured number.
By their numbers in this assay, from the lowest: compounds 1, 4, 2 and 3 (each within the scatter of the next).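

Within the data shown here, the pair gives the first step that can be read at a single place: a number 2.5 percentage points lower from compound 3 to compound 4 (within the scatter) in this assay. Benzyl in place of phenyl on a saturated chain carbon, six bonds along the chain from a carbonyl carbon, therefore gives no change that can be told from the scatter, and the added carbon leaves the maximal response as low as the numbers of the earlier compounds. Nothing at hand bears on the origin of this step.

From the compounds shown here alone, whether an amine or a carboxylic acid in place of the phenyl, or a longer chain, would move the response beyond the scatter remains open. A single step also shows no trend with chain length.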